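Benzyl in place of pyridinyl on the biaryl arm

The source may hold more compounds than are shown below. What is called first, only, known or untested is meant among the compounds shown, and "the series" means these compounds.

Of the compounds shown here, two have been measured. Compound 1 `COC(=O)/C=C/c1ccc2noc(-c3ccccc3)c2c1` gives 12100 nM in an assay for inhibition of inositol hexakisphosphate kinase 3 (Homo sapiens), read by colorimetric assay, coupled enzyme assay and malachite green, with a stated time of 120 min, in the presence of a further agent that is not named here (on this read-out lower numbers stand for stronger inhibition and higher numbers for weaker inhibition), while compound 2 `O=C(O)c1ccc2noc(-c3ccc(-c4cccnc4)cc3)c2c1` gives 610 nM, the lower of the two numbers, and the gap between them lies beyond the usual scatter. Compound 3 `O=C(O)c1ccc2noc(-c3ccc(Cc4ccccc4)cc3)c2c1` carries benzyl in place of pyridin-3-yl on an aromatic carbon. For the measured compounds named here, no measured pair shows this change, so its size is unknown. He expects the number for compound 3 to rise somewhat, with an estimated step of a 2.5-fold higher number from compound 2 to compound 3 (0.39 log units; beyond the scatter). His estimate for compound 3 is 1500 nM, within a range from 400 nM to 6000 nM.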

Compound 3, half-maximal inhibitory concentration: 1290 nM
Estimate against measurement, compound 3: 1.2-fold (0.07 log units) above; the range from low to high includes it.
By their numbers in this assay, from the lowest: compound 2; then compound 3; then compound 1.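

Replacing pyridin-3-yl with benzyl at this place, para to a large group, costs only a modest step, a 2.1-fold higher number from compound 2 to compound 3 (0.33 log units; beyond the scatter), so the position still accepts a six-membered aromatic ring of carbon only, at some loss. This single change alters both the ring and its attachment, and nothing on hand accounts for the step. Pyridin-3-ylmethyl would keep the ring nitrogen together with the methylene link, so it could separate those two parts of the change. From the compounds shown here alone, how an amine on the benzyl ring would act also remains open.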